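This account rests on a few compounds, and the source may have more. Where it says the series, first, only, none or still open, it means among the compounds named here.

Measured so far:
Compound 1 `COc1cc(OC)c(-c2coc3cc(OCC(=O)c4cccc(C(F)(F)F)c4)ccc3c2=O)cc1OC`: > 10000 nM (a limit of the assay)
Compound 2 `COc1cc(OC)c(-c2coc3cc(OCc4ccccc4F)ccc3c2=O)cc1OC`: 1610 nM
Compound 3 `COc1cc(OC)c(-c2coc3cc(OCc4cccc(Cl)c4)ccc3c2=O)cc1OC`: 2280 nM

For the measured compounds named here, in a functional assay on B16 cells (Mus musculus) for antiproliferative activity, read by MTT assay, with a stated time of 24 h (a lower number here means a stronger inhibitor, a higher number a weaker inhibitor), compound 3 gives 2280 nM and sits with compound 2, the only other compound with a true number. The step between them is a 1.4-fold higher number from compound 2 to compound 3 (0.15 log units; within the scatter), within the scatter. Compound 4 `COc1cc(OC)c(-c2coc3cc(OCc4ccccc4Cl)ccc3c2=O)cc1OC` carries 2-chlorophenyl in place of 3-chlorophenyl on a saturated chain carbon bound to an oxygen on an aromatic ring.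

The nearest evidence is the step just given, where 3-chlorophenyl replaced 2-fluorophenyl at the same place without a change beyond the scatter. The larger steps, an at least 6.2-fold lower number from compound 1 to compound 2 (0.79 log units; beyond the scatter) and an at least 4.3-fold lower number from compound 1 to compound 3 (0.64 log units; beyond the scatter), start from a limit and remove the carbonyl group of compound 1, a change unlike this one, so they bear on it little. No step beyond the scatter is therefore expected in this assay, and the expected change is a 1.1-fold lower number from compound 3 to compound 4 (0.06 log units; within the scatter). For compound 4 the estimated value is 2000 nM, with an expected range of 900 nM to 4500 nM.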

Compound 4, half-maximal inhibitory concentration: 4180 nM
Beside the measured number, compound 4's estimate is 2.1-fold (0.32 log units) below it; the measured number falls inside the stated range.
By their numbers in this assay, from the lowest: compounds 2, 3 and 4 (each within the scatter of the next, the first and the last beyond it). At a limit, above all of these: compound 1.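

In this assay, the two chlorophenyl isomers, which have the same atoms joined differently, show that this change on a saturated chain carbon bound to an oxygen on an aromatic ring gives a 1.8-fold higher number from compound 3 to compound 4 (0.26 log units; within the scatter). For the compounds shown here, the halogen itself gives the first step beyond the scatter among the compounds without a carbonyl: chloro in place of fluoro on an aromatic carbon gives a 2.6-fold higher number from compound 2 to compound 4 (0.41 log units; beyond the scatter), a modest step. The remaining step, an at least 2.3-fold lower number from compound 1 to compound 4 (0.37 log units; beyond the scatter), gives only a bound, as compound 1 stands at a limit of the assay: the limit of > 10000 nM in this assay, at which 1 of the 4 values shown sits.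

The compounds shown leave open how a bromo or methoxy group, an amine or a carboxylic acid on the phenyl ring would read in this assay. They also leave open whether the limit of compound 1 goes with its carbonyl or its trifluoromethyl, as the two enter in one change.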